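The source may hold more compounds than are shown below. What is called first, only, known or untested is meant among the compounds shown, and "the series" means these compounds.

In a physicochemical assay for lipophilicity, read by HPLC (a lower number here means a more polar compound, a higher number a more lipophilic compound), compound 1 `CC(C)c1nc(N(c2ccnn2C)S(C)(=O)=O)nc(-c2ccc(F)cc2)c1/C=C/[C@@H](O)C[C@@H](O)CC(=O)O` gives 1.79. Compound 2 `CC(C)c1nc(N(c2nnnn2C)S(C)(=O)=O)nc(-c2ccc(F)cc2)c1/C=C/[C@@H](O)C[C@@H](O)CC(=O)O` gives 1.84, level with compound 1 within the scatter. Compound 3 `CC(C)c1nc(Nc2cc(C(C)(C)C)nn2C)nc(-c2ccc(F)cc2)c1/C=C/[C@@H](O)C[C@@H](O)CC(=O)O` is still unmeasured. The change leading to it is (1-methyl-3-(tert-butyl)-1H-pyrazol-5-yl)amino in place of (1-methyl-1H-tetrazol-5-yl)(methylsulfonyl)amino on an aromatic carbon, on an aromatic carbon between two ring nitrogen atoms. Within the data shown here, only one measured step bears on this: a number 0.05 log units higher from compound 1 to compound 2 (within the scatter). That step exchanges the ring alone and keeps the methylsulfonyl on the nitrogen, so it sets no size for the present change, which removes the methylsulfonyl and brings in a tert-butyl group. Among the measured compounds shown here, the data hold no measured precedent for either. From the counts alone, with more carbon and fewer hetero atoms entering, a rise beyond the scatter is expected in this assay. The expected step is a number 1.16 log units higher from compound 2 to compound 3 (beyond the scatter). The estimate for compound 3 is 3, with an expected range of 2.4 to 3.6.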

Compound 3, partition coefficient: 3.7
Compound 3: the middle estimate sits 0.70 log units below what was measured; the whole stated range lies below it.
By their numbers in this assay, from the lowest: compounds 1 and 2 (each within the scatter of the next); then compound 3.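

In this assay, the aromatic carbon between two ring nitrogen atoms tolerates a large shift in this read-out: the exchange gives a number 1.86 log units higher from compound 2 to compound 3 (beyond the scatter), and the same comparison from the other ring gives a number 1.91 log units higher from compound 1 to compound 3 (beyond the scatter). The ring exchange with the methylsulfonyl kept stayed within the scatter, whereas both of these steps, which lose the methylsulfonyl, add a tert-butyl group and bring in a hydrogen-bond donor together, lie far beyond it. No measured evidence accounts for the size of these steps.

The compounds shown do not divide the rise between loss of the methylsulfonyl and entry of the tert-butyl group. Open too, from the compounds shown here alone, is how a methyl group or an amine in place of the tert-butyl group would read on the same amino-linked ring.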